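Taking one methoxy away from compound 2

The source may hold more compounds than are shown below. What is called first, only, known or untested is meant among the compounds shown, and "the series" means these compounds.

Compound 1 `CCCCCCCCNC(=O)[C@@H]1CSC(c2cc(OC)c(OC)c(OC)c2)N1`: 17100 nM
Compound 2 `CCCCCCCCCCCCCCNC(=O)[C@@H]1CSC(c2cc(OC)c(OC)c(OC)c2)N1`: 2000 nM

Both values come from a functional assay on cells (Homo sapiens) for antiproliferative activity, read by sulforhodamine B assay, with a stated time of 48 h; on this read-out higher numbers stand for weaker inhibition and lower numbers for stronger inhibition. Compound 2 has the lower of the two numbers, so it is the stronger inhibitor of this pair. Compound 3 `CCCCCCCCCCCCCCNC(=O)[C@@H]1CSC(c2ccc(OC)c(OC)c2)N1` keeps the chain of compound 2 but has hydrogen in place of methoxy on an aromatic carbon. Going by the values given here, the only measured step, an 8.6-fold lower number from compound 1 to compound 2 (0.93 log units; beyond the scatter), changes the chain and leaves the aromatic ring untouched, so it offers no direct guide to this change. Among the compounds with values here, no measured pair shows what removing a methoxy does. A small step is therefore expected, with uncertain direction and a somewhat higher number as the best guess: a 1.5-fold higher number from compound 2 to compound 3 (0.18 log units; within the scatter). In this assay, compound 3 is expected at 3000 nM, with an estimated range from 1000 nM to 9000 nM.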

Compound 3, half-maximal inhibitory concentration: 1500 nM
Beside the measured number, compound 3's estimate is 2.0-fold (0.30 log units) above it; the measured number falls inside the stated range.
By their numbers in this assay, from the lowest: compounds 3 and 2 (each within the scatter of the next); then compound 1.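

In this assay, replacing this methoxy with hydrogen gives a 1.3-fold lower number from compound 2 to compound 3 (0.12 log units; within the scatter), so the two compounds cannot be told apart on this read-out. Going by these compounds alone, this is the first reading on the aromatic ring rather than the chain, and it shows that, with the long chain of compound 2 in place, this methoxy, ortho to a methoxy group and meta to a large group, can be removed with no change beyond the scatter. Nothing at hand explains why the number holds when the group leaves.

The compounds shown leave open what an amine, a hydroxyl or a chlorine on this same carbon would do. They also leave open whether removing this methoxy would read the same on the shorter chain of compound 1, or whether the two remaining methoxy groups can be removed as well.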